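This account rests on a few compounds, and the source may have more. Where it says the series, first, only, none or still open, it means among the compounds named here.

Compound 1 `Cc1cc(O)c(C(=O)/C=C/c2ccccc2Cl)c(-c2ccccc2)c1C(=O)/C=C/c1ccccc1Cl` — in a functional assay on MCF7 cells (Homo sapiens) for cytotoxicity, read by MTT assay, with a stated time of 24 h (on this read-out lower numbers stand for stronger inhibition and higher numbers for weaker inhibition), compound 1 gives "not active" (no number reported), with no number reported.
Compound 2 `Cc1cc(O)c(C(=O)/C=C/c2cccc3ccccc23)c(-c2ccccc2)c1C(=O)/C=C/c1cccc2ccccc12` — in this assay compound 2 gives 30000 nM.

Compound 2 therefore stands as the only one of the two with a number in this assay; compound 1 offers only the statement that it was not active, so the two cannot be set against each other as a step. Compound 3 `Cc1cc(O)c(C(=O)/C=C/c2cccc3ccccc23)c(-c2ccc(Cl)cc2)c1C(=O)/C=C/c1cccc2ccccc12` differs from compound 2 in one place: chloro in place of hydrogen on an aromatic carbon. Among the compounds with values here, nothing among the measured pairs shows what a change of this kind does in this assay, so there is no measured step to lean on. Without such guidance, the expectation for the step from compound 2 to compound 3 is one that stays within the usual scatter, with no clear direction, as no change at the digits printed from compound 2 to compound 3 (within the scatter) states. Compound 3 is accordingly estimated at 30000 nM, expected to lie between 12000 nM and 80000 nM.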

Compound 3, half-maximal inhibitory concentration: 30000 nM
Compound 3: middle estimate and measured number agree at the digits printed; the range from low to high includes it.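

Changing phenyl to 4-chlorophenyl, with chloro in place of hydrogen on an aromatic carbon, gives no change at the digits printed from compound 2 to compound 3 (within the scatter) in this assay. Within the data shown here, this is the first measured step, and it shows that this position, para to a large group, can carry a chloro without a shift in the number beyond ordinary repeat variation. Nothing available explains why the value stays put, and this single step gives no reason to read an effect into the chloro.

The compounds shown leave open whether a different group at this position, such as an amine or a carboxylic acid, would also leave the number where it is. They also leave open whether chloro would behave the same way elsewhere on the shared core.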